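Replacing the anilide of compound 3 with a hydroxyamide

The compounds below may be only part of what the source reports. "The series", "measured", "known", "first", "only" and "open" are said of these compounds alone.

Measured so far:
compound 1, `CC(C)=CCCC1=CC[C@H](C(N)=O)[C@@H](c2ccccc2)C1`, > 23000 nM
compound 2, `CON(C)C(=O)[C@H]1CC=C(CCC=C(C)C)C[C@@H]1c1ccccc1`, 300 nM
compound 3, `CC(C)=CCCC1=CC[C@H](C(=O)Nc2ccc(C(=O)O)cc2)[C@@H](c2ccccc2)C1`, > 23000 nM

All three share one core and differ only in what sits on the amide carbonyl. In an assay on isolated protein for inhibition of Apoptosis regulator Bcl-2 (Homo sapiens), read by fluorescence polarization, with stated times of 5 min and 10 min (on this read-out higher numbers stand for weaker inhibition and lower numbers for stronger inhibition), compound 1 gives > 23000 nM, which is a limit of the assay and not a number. In the same assay compound 2 gives 300 nM. Compound 3 gives > 23000 nM, again a limit. Compound 3 therefore sits at the limit of > 23000 nM in this assay, at which 2 of the 3 values shown sit, so its position among the three is known only as being no stronger than that limit.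

Compound 4, `CC(C)=CCCC1=CC[C@H](C(=O)NO)[C@@H](c2ccccc2)C1`, has not been measured. It differs from compound 3 by hydroxy in place of 4-carboxyphenyl on an amide-type nitrogen. The measured steps that touch this nitrogen are an at least 76-fold lower number from compound 1 to compound 2 (1.88 log units; beyond the scatter), an at least 76-fold higher number from compound 2 to compound 3 (1.88 log units; beyond the scatter) and a step that the two limits leave unreadable from compound 1 to compound 3. Going by the values given here, compound 2, with methoxy(methyl)amino on the carbonyl carbon, is the only one with a readable number; the others stop at the limit. A hydroxy on the amide-type nitrogen resembles neither exactly, so the direction is open. Compound 4 is expected to give about 12000 nM, within 1500 nM to 60000 nM, meaning an estimated step of an at least 1.9-fold lower number from compound 3 to compound 4 (0.28 log units; that floor lies within the scatter), with a real chance that only a limit is reported.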

Compound 4, inhibition constant: 600 nM
Compound 4: the middle estimate sits 20-fold (1.30 log units) above what was measured; measured number outside the range, below it.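

In this assay, hydroxy on the amide-type nitrogen gives a readable number where 4-carboxyphenyl and hydrogen at the same place do not, with an at least 38-fold lower number from compound 3 to compound 4 (1.58 log units; beyond the scatter) and an at least 38-fold lower number from compound 1 to compound 4 (1.58 log units; beyond the scatter). Both steps are only floors, since each starts from a limit of the assay and not a number: the limit of > 23000 nM in this assay, at which 2 of the 4 values shown sit.

Against compound 2, the change to hydroxyamino gives a 2.0-fold higher number from compound 2 to compound 4 (0.30 log units; within the scatter), so a readable number on this carbonyl carbon does not depend on keeping the full methoxy(methyl)amino group.

The compounds shown do not separate the part played by the oxygen on the nitrogen from that of the methyl group. From the compounds shown here alone, a methylamino or a methoxyamino group on the same carbonyl carbon would be needed to tell them apart, and how either would read remains open.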